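The source may hold more compounds than are shown below. What is called first, only, known or untested is meant among the compounds shown, and "the series" means these compounds.

Measured so far:
compound 1, `COc1cccc(/C=N/c2ccc(OCc3ccccc3)cc2)c1O`, > 200000 nM
compound 2, `Oc1ccc(O)c(/C=N/c2ccc(OCc3ccccc3)cc2)c1`, 21300 nM
compound 3, `COc1ccc(/C=N/c2ccc(OCc3ccccc3)cc2)c(O)c1`, > 200000 nM

Within the data shown here, in a functional assay, with a stated time of 30 min (a higher number here means a weaker inhibitor, a lower number a stronger inhibitor), compound 2 gives 21300 nM, the only number obtained in this set. For compound 1 the read-out is a limit of the assay, > 200000 nM. For compound 3 the read-out is likewise a limit, > 200000 nM. Among the measured compounds shown here, the set is therefore dominated by the limit of > 200000 nM in this assay, at which 2 of the 3 values shown sit, and compound 2 stands alone as the one measurable inhibitor; no ordering among the three beyond that can be read from these numbers, and no pair differs in a single place, so no measured step exists.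

Compound 4, `Oc1ccc(Br)cc1/C=N/c1ccc(OCc2ccccc2)cc1`, has not been measured in this assay. Its difference from compound 2 is bromo in place of hydroxy on an aromatic carbon. For the measured compounds named here, with no measured step to lean on, the step of a 2.8-fold higher number from compound 2 to compound 4 (0.45 log units; beyond the scatter) is expected to run toward weaker inhibition and to exceed the scatter, with a real chance of another limit. Compound 4 is expected at 60000 nM, within 15000 nM to 200000 nM.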

Compound 4, half-maximal inhibitory concentration: > 200000 nM
Compound 4 gave a limit, no number; the forecaster's own chance of this, stated with the estimate: 35%; middle value at least 3.3-fold (0.52 log units) from the limit.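

Among these compounds, this is the first single-place comparison: on this aromatic carbon, para to a hydroxy group, bromo in place of hydroxy gives an at least 9.3-fold higher number from compound 2 to compound 4 (0.97 log units; beyond the scatter) in this assay. The step is a lower bound and is already beyond the scatter, so the hydroxy at this position goes with measurable inhibition in this pair, and bromo there does not keep it. Compound 2 remains the only compound with a number, and the others sit at one limit: the limit of > 200000 nM in this assay, at which 3 of the 4 values shown sit.

From the compounds shown here alone, how far compound 4 lies past that limit stays unknown, so the true size of the step cannot be read. Also open, going by these compounds, is whether an amino group, a carboxylic acid or a methoxy group on this carbon would keep a measurable value, which leaves unsettled how specific the link to hydroxy is.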